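Hydroxy Added to the Pendant Ring of Compound 3

A few compounds are considered here, and "the series" means these few. Any claim that something is new, unique, unknown or untested is made for them only; others in the source may bear on it.

The account concerns three compounds measured in an assay on membranes from brain for binding affinity to adenosine receptor A1 (Rattus norvegicus) (a higher number here means a weaker inhibitor, a lower number a stronger inhibitor), and one that awaits measurement. Compound 1 `COc1cc2oc(-c3ccc(O)cc3O)c(CC=C(C)C)c(=O)c2c(O)c1/C=C/C(C)C` gives 9090 nM in this assay. Compound 2 `COc1ccc(-c2oc3cc(OC)cc(OC)c3c(=O)c2OC)c(OC)c1` gives 27600 nM. Compound 3 `O=C1CC(c2ccccc2)Oc2ccccc21` gives 32000 nM, the highest of the three numbers; its value and that of compound 2 lie within the scatter of each other, whereas the number for compound 1 lies beyond the scatter below it.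

The move to compound 4 `O=C1CC(c2ccccc2O)Oc2ccccc21` is a single change: hydroxy in place of hydrogen on an aromatic carbon. Within the data shown here, no pair among the measured compounds differs in one place only, so there is no measured step of this kind to lean on; the data give only the three values. Among the measured compounds shown here, what can be said is that compound 1, the one carrying hydroxy groups, gives 9090 nM, while compound 2 and compound 3, which carry no hydroxy group, sit higher. On that basis compound 4 is expected to come out somewhat lower than compound 3, and the step is estimated at a 2.1-fold lower number from compound 3 to compound 4 (0.33 log units; beyond the scatter), a size close to the edge of the scatter. Compound 4 is accordingly estimated at 15000 nM, within a range from 5000 nM to 45000 nM.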

Compound 4, inhibition constant: 2640 nM
Compound 4: middle estimate off by 5.7-fold (0.75 log units), on the high side; measured number outside the range, below it.
By their numbers in this assay, from the lowest: compound 4; then compound 1; then compounds 2 and 3 (each within the scatter of the next).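

In this assay, among these compounds, hydroxy in place of hydrogen on an aromatic carbon, ortho to a large group, gives a 12-fold lower number from compound 3 to compound 4 (1.08 log units; beyond the scatter) as a large step, and this is the first measured step between compounds that differ in one place only. Among the compounds shown here, it shows that this position, on a six-membered aromatic ring of carbon only, responds strongly to this change: a single added heavy atom, one oxygen, moves the number far beyond the scatter, which the earlier compounds, differing from one another in several places at once, could not show. No measurement in hand bears on why the step is this large.

The compounds shown leave open whether methoxy, an amine or a fluorine on the same aromatic carbon would give a step of similar size, and so whether the step belongs to hydroxy in particular or to any group placed there. They also leave open whether hydroxy on another carbon of that ring, or on the other aromatic ring of the shared core, would move the number as far.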